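The source may hold more compounds than are shown below. What is called first, only, known or untested is meant among the compounds shown, and "the series" means these compounds.

Values so far in a functional assay on P388 cells (Mus musculus) for antiproliferative activity; on this read-out lower numbers stand for stronger inhibition and higher numbers for weaker inhibition

Compound 1 `COc1ccc(S(=O)(=O)Nc2cccc3c(C#N)c[nH]c23)cc1` gives 0.17 ug/mL
Compound 2 `N#Cc1ccc(S(=O)(=O)Nc2cccc3c(C#N)c[nH]c23)cc1` gives 0.53 ug/mL
Compound 3 `N#Cc1c[nH]c2c(NS(=O)(=O)c3ccc(C(N)=O)cc3)cccc12` gives 2.5 ug/mL

Compound 3 has the highest number of the three and is therefore the weakest inhibitor here, with its gaps to both others beyond the scatter. Compound 4 `CS(=O)(=O)Nc1ccc(S(=O)(=O)Nc2cccc3c(C#N)c[nH]c23)cc1` keeps the shared core but carries methanesulfonamido in place of carbamoyl on an aromatic carbon, para to a large group (methanesulfonamido in place of carbamoyl on an aromatic carbon). Three measured steps changed this same place. Methoxy to carbamoyl gave a large change (a 15-fold higher number from compound 1 to compound 3 (1.17 log units; beyond the scatter)), cyano to carbamoyl a modest one (a 4.7-fold higher number from compound 2 to compound 3 (0.67 log units; beyond the scatter)), and methoxy to cyano also a modest one (a 3.1-fold higher number from compound 1 to compound 2 (0.49 log units; beyond the scatter)). Among the measured compounds shown here, compound 3, the only carbamoyl compound, gave 2.5 ug/mL against lower numbers for the other two, so a modest step towards a lower number is expected in this assay even though methanesulfonamido is untested here. The estimated change is modest (a 3.1-fold lower number from compound 3 to compound 4 (0.49 log units; beyond the scatter)). Compound 4 is estimated at 0.8 ug/mL with an expected range from 0.2 ug/mL to 3 ug/mL in this read-out.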

Compound 4, half-maximal inhibitory concentration: 3.5 ug/mL
Compound 4: middle estimate off by 4.4-fold (0.64 log units), on the low side; measured number above the stated range.
By their numbers in this assay, from the lowest: compound 1; then compound 2; then compounds 3 and 4 (each within the scatter of the next).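

In this assay, compounds 3 and 4 cannot be told apart (a 1.4-fold higher number from compound 3 to compound 4 (0.15 log units; within the scatter)), so methanesulfonamido and carbamoyl cannot be ranked at this position, even though they differ in size and atoms. Compound 4 nevertheless stands clearly apart from the compounds with cyano (a 6.6-fold higher number from compound 2 to compound 4 (0.82 log units; beyond the scatter)) and methoxy (a 21-fold higher number from compound 1 to compound 4 (1.31 log units; beyond the scatter)), which shows that carbamoyl is not alone in giving a high number here, while methoxy still gives the lowest number of the four. No measurement is available that accounts for this grouping.

On these data alone, it remains open whether an amine or a carboxylic acid at this place would give a number closer to that of compound 1 or to those of compounds 3 and 4. As far as these compounds go, it is also open whether a longer ether such as ethoxy would match methoxy.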